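Cyclohexyl to 4-chlorobenzyl on the ring amide nitrogen

This account rests on a few compounds, and the source may have more. Where it says the series, first, only, none or still open, it means among the compounds named here.

Compound 2 `CS(=O)(=O)Nc1ccc2c(c1)S(=O)(=O)N=C(C1=C(O)C3CCCC3N(C3CCCCC3)C1=O)N2` stands at a limit in an ADME assay on Huh-7 cells (Homo sapiens) for cytotoxicity, with a stated time of 72 h; a higher number here means that more compound is tolerated, a lower number that less compound is tolerated: compound 2 gives > 10000 nM, a limit of the assay and not a number. Compound 1 `CS(=O)(=O)Nc1ccc2c(c1)S(=O)(=O)N=C(C1=C(O)C3CCCC3N(Cc3ccc(F)cn3)C1=O)N2` likewise reaches only a limit, as compound 1 gives > 33000 nM. The step that the two limits leave unreadable from compound 1 to compound 2 is thus not readable. Compound 3 `CS(=O)(=O)Nc1ccc2c(c1)S(=O)(=O)N=C(C1=C(O)C3CCCC3N(Cc3ccc(Cl)cc3)C1=O)N2` differs from compound 2 by 4-chlorobenzyl in place of cyclohexyl on an amide-type nitrogen in a ring. For the measured compounds named here, the only measured step bearing on this change is unreadable from the limits the limit of > 10000 nM in this assay, at which 1 of the 2 values shown sits, and (the limit of > 33000 nM in this assay, at which 1 of the 2 values shown sits). No shift beyond the scatter is expected for compound 3 in this assay, estimated at 15000 nM (range 5000 nM to 50000 nM), an expected step that the limit leaves unreadable from compound 2 to compound 3.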

Compound 3, half-maximal cytotoxic concentration: > 10000 nM
Compound 3 gave a limit, no number; the forecaster's own chance of this, stated with the estimate: 70%; the middle value is on the limit's open side.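

In this assay compound 3 gives > 10000 nM, a limit of the assay and not a number. For the compounds shown here, with compound 1 and compound 2 also at limits, no step among the three can be read. The compounds shown leave open the actual half-maximal cytotoxic concentration of each, and whether the group on the ring amide nitrogen changes it.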